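The compounds below may be only part of what the source reports. "The series", "measured", "known", "first", "only" and "open" are said of these compounds alone.

Compound 1, `CCOC(=O)c1ccc(-c2nn(Cc3ccc(Cl)cc3)c3ccccc23)cc1`, in a functional assay on cells (Platelet, Homo sapiens) for inhibition (a lower number here means a stronger inhibitor, a higher number a weaker inhibitor), gives > 10000 nM, which is a limit of the assay and not a number. Compound 2, `CCOC(=O)c1ccc(-c2nn(Cc3cccnc3)c3ccccc23)cc1`, gives > 10000 nM, again a limit. Compound 3, `CCCOC(=O)c1ccc(-c2nn(Cc3ccccc3)c3ccccc23)cc1`, gives > 10000 nM, also a limit.

Compound 3 therefore stands nowhere in particular on the numbers shown: its value is a limit, and all three values shown sit at that same limit (the limit of > 10000 nM in this assay, at which 3 of the 3 values shown sit). Going by the values given here, the one measured step, a step that the two limits leave unreadable from compound 1 to compound 2, is left unreadable by the two limits and concerns a different place on the shared core.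

Compound 4, `CCOC(=O)/C=C/c1ccc(-c2nn(Cc3ccccc3)c3ccccc23)cc1`, differs from compound 3 by 2-(ethoxycarbonyl)ethenyl in place of propoxycarbonyl on an aromatic carbon. Among the compounds with values here, no measured step bears on this change, so no direction and no size can be read from the data for the change in this assay. The expectation for compound 4 is simply that it stays at or near the limit, with a step that the limit leaves unreadable from compound 3 to compound 4 expected from compound 3. Compound 4 is thus estimated at 15000 nM, within a range from 3000 nM to 60000 nM.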

Compound 4, half-maximal inhibitory concentration: > 10000 nM
Compound 4: no number, only a limit; the forecaster's own chance of this, stated with the estimate: 80%; the middle value does not contradict the limit.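

Compound 3 and compound 4 both give only a limit of the assay and not a number, so no step can be read between them. In this assay the compounds shown leave open which change on the shared core, if any, would bring a measurable value.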